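From 2-fluorophenyl to 3-bromophenyl on the shared core

The source may hold more compounds than are shown below. What is called first, only, known or untested is meant among the compounds shown, and "the series" means these compounds.

Among the compounds with values here, in an ADME assay on NCM460 cells (Homo sapiens) for cytotoxicity, read by MTT assay, with a stated time of 24 h (on this read-out lower numbers stand for higher toxicity in this test and higher numbers for lower toxicity in this test), compound 2 `CC1(C)[C@H]2CC[C@]1(C)N(Cc1cn(-c3ccccc3F)nn1)C(=O)C2` gives 5260 nM, the lowest number of the three measured so far. Compound 3 `CC1(C)[C@H]2CC[C@]1(C)N(Cc1cn(-c3ccccc3)nn1)C(=O)C2` gives 19600 nM, and compound 1 `CC1(C)[C@H]2CC[C@]1(C)N(Cc1cn(-c3ccccc3C#N)nn1)C(=O)C2` gives 37500 nM. Compound 4 `CC1(C)[C@H]2CC[C@]1(C)N(Cc1cn(-c3cccc(Br)c3)nn1)C(=O)C2` is still unmeasured and carries 3-bromophenyl in place of 2-fluorophenyl on an aromatic nitrogen. Two modest measured steps bear on this change: hydrogen in place of fluoro gave a 3.7-fold higher number from compound 2 to compound 3 (0.57 log units; beyond the scatter), and fluoro in place of cyano gave a 7.1-fold lower number from compound 1 to compound 2 (0.85 log units; beyond the scatter). Neither involves bromo, so the size remains uncertain. A modest rise in this assay is expected, an estimated 2.5-fold higher number from compound 2 to compound 4 (0.39 log units; beyond the scatter). Compound 4 is estimated at 13000 nM, with an expected range from 4500 nM to 36000 nM.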

Compound 4, half-maximal cytotoxic concentration: 14600 nM
The estimate for compound 4 lay 1.1-fold (0.05 log units) below the measured number, within the range that was stated.
By their numbers in this assay, from the lowest: compound 2; then compounds 4, 3 and 1 (each within the scatter of the next, the first and the last beyond it).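

In this assay, 3-bromophenyl on the aromatic nitrogen gives a 2.8-fold higher number from compound 2 to compound 4 (0.44 log units; beyond the scatter) and a 2.6-fold lower number from compound 1 to compound 4 (0.41 log units; beyond the scatter), so compound 4 sits apart from both. Within the data shown here, the bromo group adds little that can be read against the bare phenyl, with a 1.3-fold lower number from compound 3 to compound 4 (0.13 log units; within the scatter), and compound 2 remains the only compound beyond the scatter of all the others. No measurement shown explains these differences.

Going by these compounds, it remains open whether the low number of compound 2 belongs to fluoro itself or to where it sits on the phenyl ring. On these data alone, how a methoxy group or an amine on that ring would read is also open.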